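Side-chain ester change at compound 3

The compounds below may be only part of what the source reports. "The series", "measured", "known", "first", "only" and "open" are said of these compounds alone.

Measured in a functional assay on DU-145 cells (Homo sapiens) for cytotoxicity, read by MTT assay; on this read-out lower numbers stand for stronger inhibition and higher numbers for weaker inhibition
- compound 1 (`CC(C)=CC[C@@H](OC(=O)CCO)C1=CC(=O)c2c(O)ccc(O)c2C1=O`) : 55300 nM
- compound 2 (`CC[C@](C)(O)CC(=O)O[C@H](CC=C(C)C)C1=CC(=O)c2c(O)ccc(O)c2C1=O`) : 20500 nM

Compound 2 holds the lower of the two numbers, and compound 1 is its nearest neighbour. Compound 3 (`CCCCC(CC(=O)O[C@H](CC=C(C)C)C1=CC(=O)c2c(O)ccc(O)c2C1=O)OC(C)=O`) carries 1-acetoxypentyl in place of 1-hydroxy-1-methylpropyl on a saturated chain carbon bound to a carbonyl carbon. Going by the values given here, only one measured step bears on this place, namely a 2.7-fold lower number from compound 1 to compound 2 (0.43 log units; beyond the scatter). That step is modest but beyond the scatter. Among the compounds with values here, a single step sets no trend, and no measured compound carries the acetoxy group, so the direction is tentative. In this assay a further modest drop is expected, estimated as a 2.3-fold lower number from compound 2 to compound 3 (0.36 log units; beyond the scatter). The estimate for compound 3 is 9000 nM (expected range 3000 nM to 27000 nM) .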

Compound 3, half-maximal inhibitory concentration: 67700 nM
The estimate for compound 3 lay 7.5-fold (0.88 log units) below the measured number; measured number outside the range, above it.
By their numbers in this assay, from the lowest: compound 2; then compounds 1 and 3 (each within the scatter of the next).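

In this assay the lower number of compound 2 does not extend to a larger side chain: a 3.3-fold higher number from compound 2 to compound 3 (0.52 log units; beyond the scatter), so this place does not respond in one direction as the group grows. Against hydroxymethyl, 1-acetoxypentyl gives a 1.2-fold higher number from compound 1 to compound 3 (0.09 log units; within the scatter), which leaves compound 1 and compound 3 indistinguishable and makes 1-hydroxy-1-methylpropyl the only one of the three groups with a step beyond the scatter relative to both others. No supporting data account for this difference.

The acetoxy group and the pentyl chain enter together, so the compounds shown do not separate their contributions to the step. Going by these compounds, how 1-hydroxypentyl or 1-aminopentyl would read at this place on a saturated chain carbon bound to a carbonyl carbon remains open.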